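Benzylamino replaced by a pyrrolidine-bearing chain

A few compounds are considered here, and "the series" means these few. Any claim that something is new, unique, unknown or untested is made for them only; others in the source may bear on it.

Measured so far:
Compound 1 `CSc1nc(NCc2ccccc2)c2c(n1)C(=O)C(c1ccccc1)=[N+]2[O-]` gives 36000 nM in a functional assay on HeLa cells (Homo sapiens) for antiproliferative activity, read by sulforhodamine B assay, with a stated time of 48 h; on this read-out lower numbers stand for stronger inhibition of growth and higher numbers for weaker inhibition of growth.
Compound 2 `Nc1nc(NCc2ccccc2)nc2c1[N+]([O-])=C(c1ccccc1)C2=O` gives 29000 nM in this assay.

Compound 2 and compound 1 differ at two places, so their values are only set side by side; the number for compound 2 lies within the scatter of that for compound 1. Compound 3 `Nc1nc(NCCN2CCCC2)nc2c1[N+]([O-])=C(c1ccccc1)C2=O` carries (pyrrolidin-1-yl)methyl in place of phenyl on a saturated chain carbon bound to a nitrogen on an aromatic ring. Going by the values given here, no comparable step between measured compounds exists, so the size of the change can only be guessed. The step from compound 2 to compound 3 in this assay is expected to be small, a 1.2-fold lower number from compound 2 to compound 3 (0.06 log units; within the scatter), not beyond the scatter. Compound 3 is estimated at 25000 nM, between 8000 nM and 80000 nM.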

Compound 3, concentration for 50% growth inhibition: 16000 nM
The estimate for compound 3 lay 1.6-fold (0.19 log units) above the measured number, and the stated range covers the measured number.
By their numbers in this assay, from the lowest: compounds 3, 2 and 1 (each within the scatter of the next, the first and the last beyond it).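

In this assay, exchanging benzylamino for (2-(pyrrolidin-1-yl)ethyl)amino gives a 1.8-fold lower number from compound 2 to compound 3 (0.26 log units; within the scatter). At this position, then, the phenyl ring can give way to a non-aromatic ring carrying a nitrogen without a step beyond the scatter. Nothing at hand bears on what lies behind this step.

As far as these compounds go, whether a morpholine or a dimethylamino group at the end of the chain would move the number beyond the scatter remains open. So does the outcome of a longer chain carrying the same pyrrolidine.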